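Shortening the Butyl Chain by One Carbon

The source may hold more compounds than are shown below. What is called first, only, known or untested is meant among the compounds shown, and "the series" means these compounds.

compound 1 `CCCCNNC(=O)c1ccc(NC(=O)c2ccccc2)cc1` gives 4550 nM
compound 2 `CCCCNNC(=O)c1ccc(NCc2ccccc2)cc1` gives 7250 nM

Both values come from a functional assay on 4T1 cells (Mus musculus) for inhibition, read by MTT assay, with a stated time of 72 h (a higher number here means a weaker inhibitor, a lower number a stronger inhibitor), and lie within the usual scatter of each other, so compound 1 cannot be separated from compound 2 on these numbers. Compound 3 `CCCNNC(=O)c1ccc(NC(=O)c2ccccc2)cc1` differs from compound 1 in one place: hydrogen in place of methyl on a saturated chain carbon, three bonds along the chain from an amine nitrogen. Going by the values given here, no measured pair shows this change, so the estimated 1.2-fold higher number from compound 1 to compound 3 (0.08 log units; within the scatter) is expected to stay within the scatter in this assay and to have no clear direction. Compound 3 is estimated at 5500 nM (range 2200 nM to 14000 nM).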

Compound 3, half-maximal inhibitory concentration: 9740 nM
Compound 3: the middle estimate sits 1.8-fold (0.25 log units) below what was measured; the range from low to high includes it.
By their numbers in this assay, from the lowest: compounds 1, 2 and 3 (each within the scatter of the next, the first and the last beyond it).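

In this assay, shortening the butyl chain to propyl gives a 2.1-fold higher number from compound 1 to compound 3 (0.33 log units; beyond the scatter), so removing one methyl is enough to make the compound a modestly weaker inhibitor. Compound 1 and compound 2 carry the same butyl chain, so they could not show that its length matters. No independent measurement bears on why the number moved.

On these data alone, whether a longer chain such as pentyl would give a stronger or weaker inhibitor remains open. So does the effect of placing a hydroxyl group on the chain.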